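This account rests on a few compounds, and the source may have more. Where it says the series, first, only, none or still open, it means among the compounds named here.

Series notes: compound 1 `C=C(Br)C(=O)Nc1cccc(-c2cn3nc(CCc4ccccc4)sc3n2)c1` and compound 2 `C=C(Br)C(=O)Nc1cccc(-c2cn3nc(Cc4ccccc4)sc3n2)c1` share the bromoacrylamide and the fused bicyclic core and differ only in the linker to the terminal phenyl. In a functional assay on HeLa cells (Homo sapiens) for inhibition, read by cell counting, with a stated time of 4 days (on this read-out higher numbers stand for weaker inhibition and lower numbers for stronger inhibition), compound 1 gives 3300 nM, and compound 2 gives 4500 nM; the step of a 1.4-fold higher number from compound 1 to compound 2 (0.13 log units; within the scatter) lies within the scatter, so the two numbers are not distinguishable. Going by the values given here, compound 2 stands with compound 1 as its only neighbour, and at the same level.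

Compound 3 `C=C(Br)C(=O)Nc1cccc(-c2cn3nc(-c4ccc(CC)cc4)sc3n2)c1` carries 4-ethylphenyl in place of benzyl on an aromatic carbon. Among the compounds with values here, the sole measured step, a 1.4-fold higher number from compound 1 to compound 2 (0.13 log units; within the scatter), bears on it only loosely: it shows that shortening the saturated chain by one carbon left this assay unchanged. Within the data shown here, no measured step removes the chain entirely, so the aryl attached directly to the core is untested. The estimated step of a 1.3-fold lower number from compound 2 to compound 3 (0.11 log units; within the scatter) is therefore expected to stay within the scatter, with a wide range. Compound 3 is expected to give 3500 nM in this assay, between 1200 nM and 10000 nM.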

Compound 3, half-maximal inhibitory concentration: 3200 nM
For compound 3 the middle estimate is 1.1-fold (0.04 log units) above the measured one; the measured number falls inside the stated range.
By their numbers in this assay, from the lowest: compounds 3, 1 and 2 (each within the scatter of the next).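

In this assay the step of a 1.4-fold lower number from compound 2 to compound 3 (0.15 log units; within the scatter) puts 4-ethylphenyl in place of benzyl on the aromatic carbon, and the step of a 1.0-fold lower number from compound 1 to compound 3 (0.01 log units; within the scatter) puts the same group in place of phenethyl there. An aryl group bound directly to the shared core therefore sits at the same level as the two saturated-chain compounds, so this position now shows no difference across three linkages. Loss of the chain and gain of the ethyl group arrive together in compound 3 and cannot be read apart, and no further measurement bears on the result.

Open, as far as these compounds go, is whether any group at this carbon moves the number beyond the scatter, as all three end in a carbon-only aromatic ring. An amine, a carboxylic acid or a pyridine ring there would test this.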